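From 4-chlorophenoxy to 4-acetylphenoxy in compound 3

The compounds below may be only part of what the source reports. "The series", "measured", "known", "first", "only" and "open" are said of these compounds alone.

Compound 1 `CC(Nc1ccccc1Oc1cccc(F)c1)=C1C(=O)CC(c2ccccc2)CC1=O`: 550 nM
Compound 2 `CC(Nc1ccccc1Oc1ccc(Cl)cc1)=C1C(=O)CC(c2ccccc2)CC1=O`: 500 nM

In a functional assay on HeLa cells (Homo sapiens) for antiproliferative activity, read by cell counting, with a stated time of 3 days (on this read-out lower numbers stand for stronger inhibition and higher numbers for weaker inhibition), compound 2 gives 500 nM, level with compound 1 within the scatter. Compound 3 `CC(=O)c1ccc(Oc2ccccc2NC(C)=C2C(=O)CC(c3ccccc3)CC2=O)cc1` differs from compound 2 by acetyl in place of chloro on an aromatic carbon. Among the measured compounds shown here, the only measured step, a 1.1-fold lower number from compound 1 to compound 2 (0.04 log units; within the scatter), lies within the scatter, and no measured compound carries an acetyl, so that step is weak guidance. No step beyond the scatter is expected in this assay. The estimated change is a 1.2-fold higher number from compound 2 to compound 3 (0.08 log units; within the scatter). For compound 3 the expected value is 600 nM, with an estimated range of 220 nM to 1600 nM.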

Compound 3, half-maximal inhibitory concentration: 130 nM
For compound 3 the middle estimate is 4.6-fold (0.66 log units) above the measured one; measured number below the stated range.
By their numbers in this assay, from the lowest: compound 3; then compounds 2 and 1 (each within the scatter of the next).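

In this assay, acetyl in place of chloro on this aromatic carbon gives a clear change (a 3.8-fold lower number from compound 2 to compound 3 (0.59 log units; beyond the scatter)), and 4-acetylphenyl in place of 3-fluorophenyl gives a similar one (a 4.2-fold lower number from compound 1 to compound 3 (0.63 log units; beyond the scatter)). Among the compounds shown here, compound 1 and compound 2 had stayed level within the scatter, so this is the first sign that the group on this ring can shift the number beyond it. Nothing shown here explains the change. As far as these compounds go, whether a methyl ester, a carboxylic acid or an amine at this place would match acetyl remains open, as does whether acetyl would give the same step elsewhere on the ring.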